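The compounds below may be only part of what the source reports. "The series", "measured", "known", "first", "only" and "open" are said of these compounds alone.

Working notes on the series. Compound 1 `CN1CCN(c2ccc(Nc3ncc4nc(Nc5ccc(F)cc5)n([C@H]5CCCN(S(=O)(=O)C6CC6)C5)c4n3)cc2)CC1` gives 8.6 nM in a functional assay on HCC827 cells (Homo sapiens) for antiproliferative activity, read by MTT assay, with a stated time of 72 h; on this read-out lower numbers stand for stronger inhibition and higher numbers for weaker inhibition. Within the data shown here, compound 2 `CN1CCN(c2ccc(Nc3ncc4nc(Nc5ccc(F)cc5)n(-c5cccc(NC(=O)CO)c5)c4n3)cc2)CC1` gives 7.5 nM in this assay; the single recorded step, a 1.1-fold lower number from compound 1 to compound 2 (0.06 log units; within the scatter), concerns the group on the aromatic nitrogen and leaves the anilino ring untouched. Compound 3 `CN1CCN(c2ccc(Nc3ncc4nc(Nc5ccccc5)n([C@H]5CCN(C(=O)OC(C)(C)C)C5)c4n3)cc2)CC1` gives 110 nM in this assay, the highest number of the three; compound 1 and compound 2 both stand well lower, and both carry the 4-fluorophenyl group together with a different group on the aromatic nitrogen, so their gap to compound 3 cannot be assigned to either change alone. Compound 4 `CN1CCN(c2ccc(Nc3ncc4nc(Nc5ccc(F)cc5)n([C@H]5CCN(C(=O)OC(C)(C)C)C5)c4n3)cc2)CC1` is not yet measured. It differs from compound 3 by fluoro in place of hydrogen on an aromatic carbon. Among the measured compounds shown here, no measured step isolates this change: the one recorded step, a 1.1-fold lower number from compound 1 to compound 2 (0.06 log units; within the scatter), sits at a different position, and the pair of compound 3 with compound 1 or compound 2 differs in two places. With nothing bearing on it directly, the step expected for compound 4 is set near zero, a 1.4-fold lower number from compound 3 to compound 4 (0.14 log units; within the scatter), meaning a number within the scatter of compound 3 is expected. The estimate for compound 4 in this assay is 80 nM, with a range from 30 nM to 200 nM.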

Compound 4, half-maximal inhibitory concentration: 580 nM
For compound 4 the middle estimate is 7.3-fold (0.86 log units) below the measured one, outside the stated range (above it).
By their numbers in this assay, from the lowest: compounds 2 and 1 (each within the scatter of the next); then compound 3; then compound 4.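

In this assay, the change from phenyl to 4-fluorophenyl now has its first isolated read, a 5.3-fold higher number from compound 3 to compound 4 (0.72 log units; beyond the scatter), and so fluoro in place of hydrogen, para to a large group, is not silent at this position but goes with weaker inhibition when 1-(tert-butoxycarbonyl)pyrrolidin-3-yl sits on the aromatic nitrogen. With the 4-fluorophenyl group held constant, the group on the aromatic nitrogen carries far larger steps, a 77-fold higher number from compound 2 to compound 4 (1.89 log units; beyond the scatter) and a 67-fold higher number from compound 1 to compound 4 (1.83 log units; beyond the scatter), so the fluoro group by itself does not bring low numbers, and in this pair of comparisons the 1-(tert-butoxycarbonyl)pyrrolidin-3-yl group stands with the much weaker inhibition. Nothing at hand gives a measured reason for either the fluoro step or the steps at the aromatic nitrogen.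

From the compounds shown here alone, whether fluoro costs as much alongside 1-(cyclopropylsulfonyl)piperidin-3-yl or 3-(((hydroxymethyl)carbonyl)amino)phenyl stays open, since neither group appears here with an unsubstituted anilino ring. Also open, going by these compounds, is whether the step belongs to fluoro alone or would follow other groups at the same place on the ring, such as chloro, methoxy or a nitrile.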